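Quinoline ether amides: lipophilicity notes on a hydrazide replacement

The source may hold more compounds than are shown below. What is called first, only, known or untested is meant among the compounds shown, and "the series" means these compounds.

Three members of the series have been read in a physicochemical assay for lipophilicity, read by HPLC, in phosphate buffer, measured as chromatographic lipophilicity, at pH 7.4; a higher number here means a more lipophilic compound, a lower number a more polar compound. Compound 1 `Cc1cc(C)cc(NC(=O)COc2cc(C)nc3ccccc23)c1` gives 5.39. Compound 2 `COc1ccc2nc(C)cc(NCC(=O)Nc3cc(C)cc(C)c3)c2c1`, which carries an amine linker where the others carry an ether, gives 3.59. Compound 3 `COc1ccc2nc(C)cc(OCC(=O)Nc3cc(C)ccc3C)c2c1` gives 5.05, which places it second of the three: its number lies under that of compound 1 and well over that of compound 2, both gaps beyond the scatter.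

Compound 4 `COc1ccc2nc(C)cc(OCC(=O)NNC(=O)c3ccncc3)c2c1` has not yet been measured. Against compound 3 the change is ((pyridin-4-yl)carbonyl)amino in place of 2,5-dimethylphenyl on an amide-type nitrogen; the 2,5-dimethylphenyl on the amide-type nitrogen is exchanged for ((pyridin-4-yl)carbonyl)amino, bringing in one hydrogen-bond donor and two hydrogen-bond acceptors where there were none.

Among the measured compounds shown here, no step between measured compounds matches this exchange. A downward step is nevertheless expected, and a large one, since the smaller change to the linker already sets compound 2 at 3.59; the expected step is a number 2.25 log units lower from compound 3 to compound 4 (beyond the scatter). Compound 4 is therefore estimated at 2.8, with a range from 2 to 3.6.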

Compound 4, distribution coefficient: 1.48
Compound 4: middle estimate off by 1.32 log units, on the high side; measured number below the stated range.
By their numbers in this assay, from the lowest: compound 4; then compound 2; then compound 3; then compound 1.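

The amide-type nitrogen is the first position in this series shown to carry a single-place change in this assay, and the exchange of 2,5-dimethylphenyl for ((pyridin-4-yl)carbonyl)amino gives a number 3.57 log units lower from compound 3 to compound 4 (beyond the scatter). A change at this one position can therefore move the number by a large amount, even though the heavy-atom count barely shifts, from 8 to 9. Among the compounds shown here, the exchange alters the ring, the carbonyl and the hydrogen-bond donor and acceptor counts together, and nothing measured so far accounts for the size of the step.

How the step divides among these parts remains open: benzoylamino on the same nitrogen would keep the carbonyl and replace the pyridine ring with a carbon-only one, while pyridin-4-yl directly on that nitrogen would remove the carbonyl and its amino unit. Whether the same exchange moves the number as far on the core of compound 1 is also unresolved.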